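Oxime ether variation on a prenylated series: compound 3 to compound 4

A few compounds are considered here, and "the series" means these few. Any claim that something is new, unique, unknown or untested is made for them only; others in the source may bear on it.

Measured so far in a functional assay on CEM/s cells (Homo sapiens) for cytotoxicity; a higher number here means a weaker inhibitor, a lower number a stronger inhibitor:
compound 1 `CO/N=c1\[nH]cnc2c1[n+](Cc1ccccc1)cn2C`: > 80000 nM
compound 2 `Cn1c[n+](Cc2ccccc2)c2/c(=N/OC(C)(C)C)[nH]cnc21`: "not determined" (no result reported)
compound 3 `CO/N=c1\[nH]cnc2ncn(C/C=C(\C)CC/C=C(\C)CC/C=C(\C)CCC=C(C)C)c12`: 5690 nM

Within the data shown here, compound 3 holds the only measured number in this assay. Compound 1 gives > 80000 nM in this assay, which is a limit of the assay and not a number. Compound 2 has no result in this assay. The one further point of reference is the limit of > 80000 nM in this assay, at which 1 of the 3 values shown sits; compound 3 sits clearly on the more potent side of it, while compound 1 sits at it. Among the measured compounds shown here, no step between two measured compounds is available, so nothing measured tells how a change at the oxime ether end moves the read-out.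

Compound 4 `CC(C)=CCC/C(C)=C/CC/C(C)=C/CC/C(C)=C/Cn1cnc2nc[nH]/c(=N\OCc3ccccc3)c21` differs from compound 3 in one place: phenyl in place of hydrogen on a saturated chain carbon bound to an oxygen. The chain on the ring is kept. For the measured compounds named here, with no measured step to lean on, the step from compound 3 to compound 4 is expected to be small, a 1.4-fold lower number from compound 3 to compound 4 (0.15 log units; within the scatter), with a mild lean towards a stronger inhibitor that is not beyond the scatter. Compound 4 is therefore expected at 4000 nM, within 1500 nM to 15000 nM.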

Compound 4, half-maximal inhibitory concentration: 20400 nM
Estimate against measurement, compound 4: 5.1-fold (0.71 log units) below, and the stated range ends below it.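

In this assay the oxime ether end now has a measured step, methoxy to benzyloxy with the chain on the ring kept, which gives a 3.6-fold higher number from compound 3 to compound 4 (0.55 log units; beyond the scatter) and so points towards a weaker inhibitor, not a stronger one. This shows that the position responds to the change, although the reading rests on this single pair and sets no trend for oxime ethers in general. Compound 4 still gives a measured number, and the only other reference point is a limit and not a number, held by compound 1: the limit of > 80000 nM in this assay, at which 1 of the 4 values shown sits.

Going by these compounds, what an ethoxy group or a longer alkoxy chain would give at this position stays open, so it is unclear whether the step builds gradually from methoxy to benzyloxy. Also open, on these data alone, is whether an amine on the phenyl ring of the benzyloxy group would move the read-out in either direction.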